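This account rests on a few compounds, and the source may have more. Where it says the series, first, only, none or still open, it means among the compounds named here.

Values in a functional assay on NCI-H460 cells (Homo sapiens) for cytotoxicity, read by MTT assay, with a stated time of 48 h; a higher number here means a weaker inhibitor, a lower number a stronger inhibitor
- compound 1 `COc1ccc(/C=C/C(=O)/C=C/c2nc3ccccc3n2C)cc1O` gives 6900 nM
- compound 2 `COc1ccc(/C=C/C(=O)/C=C/c2nc3c(C)cccc3n2C)cc1O` gives 25400 nM

Of these two numbers, compound 1 holds the lower, which makes it the stronger inhibitor of the pair. The next compound to be tested is compound 3 `COc1ccc2c(c1)nc(/C=C/C(=O)/C=C/c1ccc(OC)c(O)c1)n2C`, and it differs from compound 1 in one place: methoxy in place of hydrogen on an aromatic carbon. In words, a methoxy replaces a hydrogen on an aromatic carbon of the core. Among the compounds with values here, only one measured step bears on this change: a 3.7-fold higher number from compound 1 to compound 2 (0.57 log units; beyond the scatter). There, a methyl replaced a hydrogen on an aromatic carbon, and the number rose. A single step with a different group is thin evidence, so a rise in this assay is expected in the same direction but smaller, and it may not clear the scatter. The estimated change is a 1.4-fold higher number from compound 1 to compound 3 (0.16 log units; within the scatter). Compound 3 is expected at 10000 nM, within an estimated range of 4000 nM to 26000 nM.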

Compound 3, half-maximal inhibitory concentration: 11700 nM
Beside the measured number, compound 3's estimate is 1.2-fold (0.07 log units) below it; the range from low to high includes it.
By their numbers in this assay, from the lowest: compounds 1 and 3 (each within the scatter of the next); then compound 2.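

In this assay, a methoxy on this aromatic carbon of the core gives a 1.7-fold higher number from compound 1 to compound 3 (0.23 log units; within the scatter), which cannot be told apart from the ordinary variation between repeated measurements. The methyl change gave a different result, a 3.7-fold higher number from compound 1 to compound 2 (0.57 log units; beyond the scatter), so adding a group to an aromatic carbon of this six-membered ring does not always produce a step beyond the scatter. Nothing available here explains the difference between these two steps.

As far as these compounds go, it remains open how an amine, a carboxylic acid or a longer chain such as ethoxy on this same carbon would change the number. With a single methoxy step inside the scatter, the data also cannot show whether this carbon accepts larger groups in general.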